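From pentyl to cyclohexyl amide: another limit expected

The source may hold more compounds than are shown below. What is called first, only, known or untested is meant among the compounds shown, and "the series" means these compounds.

Compound 3 `CCCCCNC(=O)c1n[nH]cc1NC(=O)c1c(OC)cccc1OC` carries a pentyl group on an amide-type nitrogen of the shared core. In an ADME assay on MRC5 cells (Homo sapiens) for inhibition, with a stated time of 72 h (on this read-out higher numbers stand for an effect only at larger amounts of compound and lower numbers for an effect already at smaller amounts), compound 3 gives > 50000 nM, which is a limit of the assay and not a number. Compound 1 `COc1cccc(OC)c1C(=O)Nc1c[nH]nc1C(=O)Nc1ccncc1` gives > 50000 nM in this assay, again only a limit. Compound 2 `COc1cccc(OC)c1C(=O)Nc1c[nH]nc1C(=O)O` gives > 50000 nM, also a limit. The steps a step that the two limits leave unreadable from compound 1 to compound 2, a step that the two limits leave unreadable from compound 1 to compound 3 and a step that the two limits leave unreadable from compound 2 to compound 3 are thus unreadable in size, and the limit of > 50000 nM in this assay, at which 3 of the 3 values shown sit, shows every value at the same limit. Compound 4 `COc1cccc(OC)c1C(=O)Nc1c[nH]nc1C(=O)NC1CCCCC1` differs from compound 3 by cyclohexyl in place of pentyl on an amide-type nitrogen. Going by the values given here, no measured step bears on this exchange with a readable size. Compound 4 is therefore expected to give 50000 nM, between 20000 nM and 100000 nM, most probably once more as a limit. The expected step is a number no higher from compound 3 to compound 4 (the limit leaves the size open), with no direction beyond the scatter.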

Compound 4, half-maximal effective concentration: 35000 nM
Estimate against measurement, compound 4: 1.4-fold (0.15 log units) above; measured number inside the range.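

In this assay, compound 4, with cyclohexyl on the amide-type nitrogen, is the only compound shown to give a number and not a limit. Going by these compounds alone, this gives the first steps with a floor: an at least 1.4-fold lower number from compound 3 to compound 4 (0.15 log units; that floor lies within the scatter), an at least 1.4-fold lower number from compound 2 to compound 4 (0.15 log units; that floor lies within the scatter) and an at least 1.4-fold lower number from compound 1 to compound 4 (0.15 log units; that floor lies within the scatter). The steps among the other compounds still cannot be read.

On these data alone, whether a cyclopentyl or piperidin-4-yl group on the same nitrogen would also give a number in this assay remains open. The true size of all three new steps also remains open: the limit of > 50000 nM in this assay, at which 3 of the 4 values shown sit.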